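Allyl for methoxycarbonyl on the core of compound 1

This account rests on a few compounds, and the source may have more. Where it says the series, first, only, none or still open, it means among the compounds named here.

Two compounds of this series have numbers in a functional assay with Rattus norvegicus as the target; on this read-out lower numbers stand for stronger inhibition and higher numbers for weaker inhibition. Compound 1 `COC(=O)c1cc(OC)c2oc(=O)c(=O)[nH]c2c1` gives 3400 nM in this assay, the lower of the two. Compound 2 `CCOC(=O)c1ccc2oc(=O)c(=O)[nH]c2c1` gives 10000 nM in this assay, a gap beyond the usual scatter. Compound 3 `C=CCc1cc(OC)c2oc(=O)c(=O)[nH]c2c1` is not yet measured; it differs from compound 1 in one place: allyl in place of methoxycarbonyl on an aromatic carbon. Within the data shown here, no measured pair shows a change of this kind, so the size of the step is not anchored. The step from compound 1 to compound 3 is expected to be small, a 1.2-fold higher number from compound 1 to compound 3 (0.07 log units; within the scatter), possibly within the scatter in either direction. Compound 3 is estimated at 4000 nM in this assay, within 1200 nM to 14000 nM.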

Compound 3, half-maximal inhibitory concentration: 10000 nM
Compound 3: middle estimate off by 2.5-fold (0.40 log units), on the low side; low and high end bracket the measured number.
By their numbers in this assay, from the lowest: compound 1; then compounds 2 and 3 (each within the scatter of the next).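

In this assay, allyl in place of methoxycarbonyl on this aromatic carbon, meta to the methoxy group, gives a 2.9-fold higher number from compound 1 to compound 3 (0.47 log units; beyond the scatter) and so a modest loss of inhibition. The position is therefore not indifferent to its substituent: swapping methoxycarbonyl, with its hydrogen-bond acceptors, for allyl, which has none, does not keep the level of compound 1. Nothing measured on these compounds accounts for the step. Still open, from the compounds shown here alone, is whether a carboxylic acid, an amide or a saturated propyl chain here would match methoxycarbonyl or allyl.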